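A Longer Alkenyl Chain on a Compound at the Limit

This account rests on a few compounds, and the source may have more. Where it says the series, first, only, none or still open, it means among the compounds named here.

In a functional assay on PK9 cells (Homo sapiens) for inhibition, read by MTT assay, with a stated time of 72 h (on this read-out higher numbers stand for weaker inhibition and lower numbers for stronger inhibition), compound 2 (`C=CCCCCCCOC[C@@H]1CCCN1C(=O)OC(C)(C)C`) gives 57100 nM. Compound 3 (`C=CCCCCCCCCCOC[C@@H]1CCCN1C(=O)OC(C)(C)C`) gives > 100000 nM, which is a limit and not a number. Compound 1 (`CCCCCC/C=C/CCCCCCCCOC[C@H]1NC[C@H](O)[C@@H]1O`), built on a core of its own, gives > 100000 nM, also a limit. Compound 3 therefore stands on (the limit of > 100000 nM in this assay, at which 2 of the 3 values shown sit), and no number fixes its place.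

Compound 4 (`CCCCCCCC/C=C\CCCCCCCCOC[C@@H]1CCCN1C(=O)OC(C)(C)C`) carries dec-1-en-1-yl in place of allyl on a saturated chain carbon, eight bonds along the chain from an oxygen on a saturated carbon.

Going by the values given here, only one measured step bears on this change, a replacement in the same chain: an at least 1.7-fold higher number from compound 2 to compound 3 (0.24 log units; that floor lies within the scatter). Among the compounds with values here, its floor lies within the scatter, so it sets no firm direction, and the data hold no measured step with a chain as long as that of compound 4 on this core. No step beyond the scatter is therefore expected in this assay, and a further limit is the more likely report. The expected step is a number no higher from compound 3 to compound 4 (the limit leaves the size open). For compound 4 the estimate is 100000 nM, with an expected range from 45000 nM to 200000 nM.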

Compound 4, half-maximal inhibitory concentration: > 100000 nM
Compound 4: a limit, no number; the forecaster's own chance of this, stated with the estimate: 70%; the middle value lies on the limit itself.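

Compound 3 and compound 4 are both reported in this assay only as limits and not as numbers, so no step between them can be read: the limit of > 100000 nM in this assay, at which 3 of the 4 values shown sit.

The compounds shown leave open whether dec-1-en-1-yl in place of allyl changes inhibition on this read-out at all, and where compound 3 and compound 4 would lie if given numbers.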